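Swapping the outer aryl ring on an aminoquinoline cytotoxicity series

The source may report more compounds than this note shows. Statements on the series, on what has been measured and on what is new or still open speak of the compounds shown alone.

Three compounds share one core. Compound 1, `Clc1ccc2c(NCCNc3nccc(Nc4ccc(Br)cc4)n3)ccnc2c1`, gives "not active" (no number reported) in an ADME assay on Vero cells (Chlorocebus sabaeus) for cytotoxicity, read by neutral red uptake, with a stated time of 72 h (a higher number here means a weaker inhibitor, a lower number a stronger inhibitor), so no number exists for it. Compound 2, `Clc1ccc2c(NCCCNc3nccc(Nc4ccccc4)n3)ccnc2c1`, gives 12800 nM in this assay, and compound 3, `Fc1ccc(Nc2ccnc(NCCCNc3ccnc4cc(Cl)ccc34)n2)cc1`, gives 13700 nM. Compound 3 therefore holds the higher of the two numbers available, but its step from compound 2, a 1.1-fold higher number from compound 2 to compound 3 (0.03 log units; within the scatter), lies within the scatter, so the two cannot be told apart.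

Compound 4, `COc1cc(Nc2ccnc(NCCCNc3ccnc4cc(Cl)ccc34)n2)cc(OC)c1`, differs from compound 3 by 3,5-dimethoxyphenyl in place of 4-fluorophenyl on a nitrogen on an aromatic ring. Among the measured compounds shown here, no measured pair shows this exchange. For the measured compounds named here, the one measured step, the fluoro-for-hydrogen change from compound 2 to compound 3, was within the scatter, which suggests the outer aryl ring has so far moved this number little. The expected step from compound 3 to compound 4 is therefore a 1.0-fold higher number from compound 3 to compound 4 (0.01 log units; within the scatter), with no direction beyond the scatter asserted.

Compound 4 is estimated at 14000 nM, ranging from 7000 nM to 28000 nM.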

Compound 4, half-maximal inhibitory concentration: 12900 nM
For compound 4 the middle estimate is 1.1-fold (0.04 log units) above the measured one; measured number inside the range.
By their numbers in this assay, from the lowest: compounds 2, 4 and 3 (each within the scatter of the next).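

Exchanging the outer ring on the nitrogen for 3,5-dimethoxyphenyl, which brings 10 heavy atoms and 2 hydrogen-bond acceptors where 4-fluorophenyl has 7 and 0, gives a 1.1-fold lower number from compound 3 to compound 4 (0.03 log units; within the scatter) in this assay and also a 1.0-fold higher number from compound 2 to compound 4 (0.00 log units; within the scatter) on the plain phenyl compound. The earlier compounds shown here tested only a single fluoro, whereas these steps show that a much bigger change at this position also leaves compounds 2, 3 and 4 indistinguishable, so this position tolerates both changes without a readable shift. No measurement here offers an explanation for this.

Still open, from the compounds shown here alone, is whether a charged or strongly different group on the outer ring, such as a carboxylic acid or a dimethylamino group, would move the number beyond the scatter. Also open, going by these compounds, is what a saturated cyclohexyl ring in place of the aryl ring would do.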